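This account rests on a few compounds, and the source may have more. Where it says the series, first, only, none or still open, it means among the compounds named here.

Three compounds sharing one core have been checked for cytotoxicity. Compound 1 `CCCCCC(=O)Nc1ncc(C(Oc2ccc3cc(Br)ccc3c2)c2ccc(Cl)cc2)s1` carries a hexanoyl amide; in an ADME assay on HepG2 2.2.15 cells (Homo sapiens) for cytotoxicity (on this read-out higher numbers stand for lower toxicity in this test and lower numbers for higher toxicity in this test), compound 1 reaches only the limit of > 50000 nM, which is a limit of the test rather than a number. Compound 2 `CC(C)(C)C(=O)Nc1ncc(C(Oc2ccc3cc(Br)ccc3c2)c2ccc(Cl)cc2)s1` carries a pivaloyl amide, and in this assay compound 2 is reported as "not toxic" (no number reported). Compound 3 `O=C(Nc1ncc(C(Oc2ccc3cc(Br)ccc3c2)c2ccc(Cl)cc2)s1)C1CCOCC1` carries the oxan-4-yl carbonyl amide, and in this assay compound 3 is likewise reported as "not toxic" (no number reported). Compound 3 therefore stands without a single number; of the three entries shown, one sits at the limit of > 50000 nM in this assay, at which 1 of the 3 values shown sits, and two are given only in words, so the set is uniformly without a measurable cytotoxic response.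

Compound 4 `O=C(Nc1ncc(C(Oc2ccc3cc(Br)ccc3c2)c2ccc(Cl)cc2)s1)c1ccccc1` differs from compound 3 in one place: phenyl in place of oxan-4-yl on a carbonyl carbon. Among the compounds with values here, no measured step between two compounds of this set exists, so the size of this step can only be expected. Given that compound 1, compound 2 and compound 3 all sit at or beyond the top of the test, no shift beyond the usual scatter in this assay is expected from this change. Compound 4 is accordingly expected to give about 50000 nM, within a range from 20000 nM to 100000 nM, most likely again reported as a limit.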

Compound 4, half-maximal cytotoxic concentration: "not toxic" (no number reported)
For compound 4 the study gives words and no number; the estimate stays without a comparison.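

Compound 3 and compound 4 are both reported only in words, as "not toxic", so no step can be read between them. The compounds shown leave open whether any of these amides would give a measurable cytotoxic concentration in this assay, where the only figure given is a limit and not a number: the limit of > 50000 nM in this assay, at which 1 of the 4 values shown sits.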